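Acylguanidine series: benzyloxy replacing cyclohexyl

The source may report more compounds than this note shows. Statements on the series, on what has been measured and on what is new or still open speak of the compounds shown alone.

Measured so far:
compound 1 `Cc1c(C(=O)N=C(N)N)cc(S(C)(=O)=O)c(Cl)c1C`: 58 nM
compound 2 `Cc1cc(C2CCCCC2)c(S(C)(=O)=O)cc1C(=O)N=C(N)N`: 22 nM

In a functional assay for inhibition of sodium/hydrogen exchanger (Oryctolagus cuniculus) (on this read-out higher numbers stand for weaker inhibition and lower numbers for stronger inhibition), compound 2 gives 22 nM, the lowest of the two numbers; compound 1 gives 58 nM, a gap beyond the usual scatter, so compound 2 is the stronger inhibitor of the pair. Compound 3 `Cc1cc(OCc2ccccc2)c(S(C)(=O)=O)cc1C(=O)N=C(N)N` is not yet measured. It differs from compound 2 in one place: benzyloxy in place of cyclohexyl on an aromatic carbon. Among the measured compounds shown here, no measured step of this kind exists, so the expectation rests on the change alone. For compound 3 a small step toward a higher number, near the edge of the scatter, is expected: a 1.8-fold higher number from compound 2 to compound 3 (0.26 log units; within the scatter). The estimate for compound 3 in this assay is 40 nM, with a range from 12 nM to 130 nM.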

Compound 3, half-maximal inhibitory concentration: 28 nM
Compound 3: the middle estimate sits 1.4-fold (0.15 log units) above what was measured, and the stated range covers the measured number.
By their numbers in this assay, from the lowest: compounds 2 and 3 (each within the scatter of the next); then compound 1.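

In this assay, benzyloxy in place of cyclohexyl on the aromatic carbon ortho to a methylsulfonyl group gives a 1.3-fold higher number from compound 2 to compound 3 (0.10 log units; within the scatter). This position therefore accepts an oxygen-linked aromatic ring as well as a saturated carbon ring, and the two compounds cannot be separated on this read-out. No available evidence accounts for this result.

Still open, as far as these compounds go, is how an amine or a carboxylic acid would read on this carbon. Also open, from the compounds shown here alone, is whether phenoxy or a longer chain such as 2-phenylethoxy would hold the same level.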